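The source may hold more compounds than are shown below. What is called first, only, known or untested is meant among the compounds shown, and "the series" means these compounds.

Values in an ADME assay on L6 cells (Rattus norvegicus) for cytotoxicity, read by resazurin assay, with a stated time of 72 h (a lower number here means a stronger inhibitor, a higher number a weaker inhibitor), measured so far
Compound 1 `CN(C)C12CC(c3ccccc3)C(CN(C(=O)CCN3CCCCC3)C1)C(c1ccccc1)C2` gives 12400 nM
Compound 2 `CCN(CC)CCC(=O)N1CC2C(c3ccccc3)CC(N(C)C)(CC2c2ccccc2)C1` gives 15400 nM
Compound 3 `CN(C)C12CC(c3ccccc3)C(CN(CCN3CCCCC3)C1)C(c1ccccc1)C2` gives 2920 nM

Compound 3 stands lowest of the three in this assay and the other two lie clearly above it, as (a 4.2-fold lower number from compound 1 to compound 3 (0.63 log units; beyond the scatter)) and (a 5.3-fold lower number from compound 2 to compound 3 (0.72 log units; beyond the scatter)) show. Both of those steps replace a carbonyl-bearing chain on the amine nitrogen in a ring, which compound 4 does not touch, so they say little about what comes next.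

Compound 4 `CN(C)C12CC(c3ccccc3)C(CN(CCN3CCCC3)C1)C(c1ccccc1)C2` differs from compound 3 in one group only (pyrrolidin-1-yl in place of piperidin-1-yl on a saturated chain carbon, two bonds along the chain from an amine nitrogen in a ring), with pyrrolidin-1-yl in place of piperidin-1-yl on a saturated chain carbon, two bonds along the chain from an amine nitrogen in a ring.

The closest measured precedent is the exchange of piperidin-1-yl for diethylamino, which gave (a 1.2-fold higher number from compound 1 to compound 2 (0.09 log units; within the scatter)) and stayed within the scatter. Going by the values given here, that step sits in the carbonyl-bearing series, and no measured compound carries pyrrolidin-1-yl, so the evidence is thin. On this basis, no step beyond the scatter is expected in this assay.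

The expected step is small (a 1.2-fold higher number from compound 3 to compound 4 (0.08 log units; within the scatter)). Compound 4 is estimated at 3500 nM (expected range 1500 nM to 8000 nM).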

Compound 4, half-maximal inhibitory concentration: 5580 nM
Beside the measured number, compound 4's estimate is 1.6-fold (0.20 log units) below it, and the stated range covers the measured number.
By their numbers in this assay, from the lowest: compounds 3 and 4 (each within the scatter of the next); then compounds 1 and 2 (each within the scatter of the next).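

In this assay, the exchange of piperidin-1-yl for pyrrolidin-1-yl, on a saturated chain carbon, two bonds along the chain from an amine nitrogen in a ring, gives a 1.9-fold higher number from compound 3 to compound 4 (0.28 log units; within the scatter), so this position tolerates the six-membered ring giving way to the five-membered one without a step beyond the scatter. Going by these compounds alone, this is the first exchange of the end amine seen on a chain without the carbonyl, and the earlier exchange, to diethylamino, was seen only on a chain with it. The gain seen for compound 3 over the carbonyl-bearing compounds also holds with the new ring, as a 2.8-fold lower number from compound 2 to compound 4 (0.44 log units; beyond the scatter) and a 2.2-fold lower number from compound 1 to compound 4 (0.35 log units; beyond the scatter) show, although each of these steps changes the end amine as well as removing the carbonyl, and nothing shown gives a reason for any of these steps.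

As far as these compounds go, whether a morpholin-4-yl group or diethylamino would also stay within the scatter of compound 3 on this chain remains open. So does the effect in this assay of a longer chain in place of 2-(pyrrolidin-1-yl)ethyl on the same ring nitrogen.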